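The source may report more compounds than this note shows. Statements on the series, on what has been measured and on what is new or still open speak of the compounds shown alone.

Measured so far in a functional assay on HCT-116 cells (Homo sapiens) for cytotoxicity, read by sulforhodamine B assay, with a stated time of 24 h; on this read-out higher numbers stand for weaker inhibition and lower numbers for stronger inhibition
Compound 1 `N#CCC(=O)N/N=C1\C(=O)Nc2ccc(S(=O)(=O)N3CCOCC3)cc21` gives 10300 nM
Compound 2 `Cc1ccc(/N=C2\C(=O)Nc3ccc(S(=O)(=O)N4CCOCC4)cc32)cc1` gives 18900 nM
Compound 3 `CC(=O)N/N=C1\C(=O)Nc2ccc(S(=O)(=O)N3CCOCC3)cc21` gives 29000 nM

On these numbers compound 3 stands with compound 2 and apart from compound 1. Going by the values given here, the only step beyond the scatter is modest: a 2.8-fold higher number from compound 1 to compound 3 (0.45 log units; beyond the scatter). The other gap is not: a 1.5-fold higher number from compound 2 to compound 3 (0.19 log units; within the scatter).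

Compound 4 `N/N=C1\C(=O)Nc2ccc(S(=O)(=O)N3CCOCC3)cc21` carries hydrogen in place of acetyl on an amine nitrogen. Among the compounds with values here, no measured step removes this acyl group outright, so the evidence is indirect. Two steps exchange the whole group on the double-bonded nitrogen, and both stay within the scatter: a 1.8-fold higher number from compound 1 to compound 2 (0.26 log units; within the scatter) and a 1.5-fold higher number from compound 2 to compound 3 (0.19 log units; within the scatter). The step that alters the acyl chain itself, a 2.8-fold higher number from compound 1 to compound 3 (0.45 log units; beyond the scatter), sets the largest size seen so far. No step beyond the scatter is therefore expected in this assay, and the estimated shift is slight, towards a lower number: a 1.5-fold lower number from compound 3 to compound 4 (0.16 log units; within the scatter).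

Compound 4 is estimated at 20000 nM, with an expected range from 8000 nM to 45000 nM.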

Compound 4, half-maximal inhibitory concentration: 36300 nM
For compound 4 the middle estimate is 1.8-fold (0.26 log units) below the measured one; the range from low to high includes it.
By their numbers in this assay, from the lowest: compounds 1, 2, 3 and 4 (each within the scatter of the next, the first and the last beyond it).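

In this assay, the first direct removal of the acyl group from this amine nitrogen, acetyl to hydrogen, stays within the scatter: a 1.3-fold higher number from compound 3 to compound 4 (0.10 log units; within the scatter). The free amino end also stays within the scatter of the 4-methylphenyl group on the double-bonded nitrogen, a 1.9-fold higher number from compound 2 to compound 4 (0.28 log units; within the scatter), but the (cyanomethyl)carbonyl group stands apart from hydrogen, a 3.5-fold higher number from compound 1 to compound 4 (0.55 log units; beyond the scatter), so among these groups only that one separates from hydrogen. Compound 2 goes against a clean split. Its own value stays within the scatter of both ends. Nothing available here accounts for these steps.

As far as these compounds go, it remains open whether a longer chain ending in nitrile would extend the modest gain seen with compound 1. From the compounds shown here alone, a carboxylic acid or a tertiary amine at the end of the acyl chain also remains untested in this set.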